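This account rests on a few compounds, and the source may have more. Where it says the series, first, only, none or still open, it means among the compounds named here.

Among the numbers recorded in an assay on isolated protein for inhibition of fatty acid synthase (Rattus norvegicus) (a lower number here means a stronger inhibitor, a higher number a weaker inhibitor), compound 1, with the structure `O=[N+]([O-])c1ccc2nc(O)c(-c3ccccc3)c(O)c2c1`, stands highest: it gives 550 nM. Its nearest neighbour is compound 3, with the structure `O=[N+]([O-])c1cc2c(O)c(-c3ccccc3)c(O)nc2cc1F`, which gives 50 nM; the change of fluoro in place of hydrogen on an aromatic carbon gives an 11-fold lower number from compound 1 to compound 3 (1.04 log units; beyond the scatter). Compound 2, with the structure `CS(=O)(=O)c1ccc2nc(O)c(-c3ccccc3)c(O)c2c1`, returns only a limit of the assay rather than a number, at > 15000 nM. The change to methylsulfonyl in place of nitro on an aromatic carbon therefore gives an at least 27-fold higher number from compound 1 to compound 2 (1.43 log units; beyond the scatter).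

Compound 4, with the structure `O=[N+]([O-])c1ccc2nc(O)cc(O)c2c1`, differs from compound 1 by hydrogen in place of phenyl on an aromatic carbon. Neither measured step touches this place: one alters the nitro group, the other adds a fluoro elsewhere on the shared core, and both leave the phenyl in place. So no recorded step speaks directly to removing it. The change takes away six heavy atoms, a larger alteration of the molecule than either measured one, and a large step toward a weaker inhibitor is expected, estimated as a 9.1-fold higher number from compound 1 to compound 4 (0.96 log units; beyond the scatter). For compound 4 the expected value in this assay is 5000 nM, within a range from 1000 nM to 20000 nM.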

Compound 4, half-maximal inhibitory concentration: > 15000 nM
Compound 4 ended at the assay's limit; the forecaster's own chance of this, stated with the estimate: 30%; middle value at least 3.0-fold (0.47 log units) from the limit.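

Taking the phenyl off the shared core is the only change shown at this position, and it produces a large loss of inhibition: an at least 27-fold higher number from compound 1 to compound 4 (1.43 log units; beyond the scatter). In this assay, the phenyl on this aromatic carbon, ortho to two hydroxy groups, therefore cannot be replaced by hydrogen without a large loss, so this position joins the nitro group as a place where a single change has a large effect on compound 1. The step gives only a minimum size rather than a full measure, because compound 4 reaches a limit of the assay and not a number: the limit of > 15000 nM in this assay, at which 2 of the 4 values shown sit.

The compounds shown carry only phenyl or hydrogen at this place, so it remains open whether a methyl group, a chloro-substituted phenyl, a benzyl group or a carboxylic acid there would keep the inhibition seen with compound 1, or lose it as hydrogen does. On these data alone, it also remains open whether the phenyl matters as much in compound 3, whose fluoro group gives it the lower number, as it does in compound 1.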